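The compounds below may be only part of what the source reports. "The series", "measured", "known", "first", "only" and "open" are said of these compounds alone.

For the measured compounds named here, compound 3 `COc1ccc(-c2cnc3nc(N)nc(N4CCN(Cc5ccccc5)CC4)c3n2)cc1OC` gives 900 nM in a functional assay on cells (T-cell, Homo sapiens) for inhibition (on this read-out lower numbers stand for stronger inhibition and higher numbers for weaker inhibition), and stands at the highest of the three numbers measured so far. Its nearest neighbour is compound 1 `COc1ccc(-c2cnc3nc(N)nc(N4CCN(C(=O)COc5ccccc5)CC4)c3n2)cc1OC`, which gives 4 nM in this assay; the furthest is compound 2 `COc1ccc(-c2cnc3nc(N)nc(N4CCN(C(=O)Nc5ccccc5)CC4)c3n2)cc1OC`, which gives 3.4 nM in this assay. Between those two the step of a 1.2-fold lower number from compound 1 to compound 2 (0.07 log units; within the scatter) is small, while the two steps onto compound 3, a 230-fold higher number from compound 1 to compound 3 (2.35 log units; beyond the scatter) and a 260-fold higher number from compound 2 to compound 3 (2.42 log units; beyond the scatter), are both large. Compound 4 `COc1ccc(-c2cnc3nc(N)nc(N4CCN(C(=O)Nc5ccc(C#N)cc5)CC4)c3n2)cc1OC` is the next compound to be measured. The change from compound 3 to compound 4 is (4-cyanophenyl)carbamoyl in place of benzyl on an amine nitrogen in a ring. This change runs the step from compound 2 to compound 3 backwards, with a nitrile added on the phenyl ring of the carbamoyl group, so the measured steps that bear on it are a 260-fold higher number from compound 2 to compound 3 (2.42 log units; beyond the scatter) and, more loosely, a 230-fold higher number from compound 1 to compound 3 (2.35 log units; beyond the scatter). A large downward step in this assay is therefore expected, of roughly the size seen in the reverse direction; the nitrile itself has no measured counterpart among these compounds. The step of a 180-fold lower number from compound 3 to compound 4 (2.26 log units; beyond the scatter) is what this expectation amounts to. For compound 4 the estimated number in this assay is 5 nM, with a range from 1.5 nM to 25 nM.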

Compound 4, half-maximal inhibitory concentration: 74 nM
Compound 4: middle estimate off by 15-fold (1.17 log units), on the low side; measured number outside the range, above it.
By their numbers in this assay, from the lowest: compounds 2 and 1 (each within the scatter of the next); then compound 4; then compound 3.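

For the compounds shown here, the earlier compounds showed only that a carbonyl-linked group on the ring amine nitrogen separates sharply from benzyl in this assay; the new result shows that this position also responds to what the phenyl ring of the carbamoyl group carries, with cyano in place of hydrogen giving a 22-fold higher number from compound 2 to compound 4 (1.34 log units; beyond the scatter) as its effect. The (4-cyanophenyl)carbamoyl group still retains part of the advantage over benzyl, with a 12-fold lower number from compound 3 to compound 4 (1.09 log units; beyond the scatter) as the measured step, but it does not match the phenoxymethyl amide, as a 19-fold higher number from compound 1 to compound 4 (1.27 log units; beyond the scatter) shows, so a carbonyl link on this nitrogen does not by itself secure a number as low as those of compound 1 and compound 2. Nothing available explains why the nitrile raises the number in this series.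

On these data alone, it remains open whether the rise belongs to the nitrile specifically or would also follow from a chlorine, a methoxy group or an amine in its place on the phenyl ring. As far as these compounds go, it is equally open whether a nitrile on the phenyl ring of the phenoxymethyl amide would raise the number in the same way.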